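The compounds below may be only part of what the source reports. "The series", "measured", "known", "first", "only" and "open" are said of these compounds alone.

Compound 1 `COc1ccc(-n2cnc(C#N)c2NC(=O)c2cc3cccc(OC)c3oc2=N)cc1` stands highest of the two compounds that have been measured in an assay on CHO cells for displacement of a labelled ligand from adenosine receptor A1 (Homo sapiens), read by scintillation counting, with a stated time of 60 min, tested at 10 uM; a higher number here means more inhibition at the concentration tested (going by the name of the read-out), a lower number less inhibition. In this assay compound 1 gives 37%. Going by the values given here, the only other measured compound, compound 2 `O=C(NCCCO)c1cc2ccccc2oc1=O`, gives 24% in this assay, a number that lies below compound 1 by more than the usual scatter; the two compounds share no single point of difference, so their gap is simply what the two values show.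

Compound 3 `COc1cccc2cc(C(=O)Nc3c(C#N)ncn3-c3ccc(C#N)cc3)c(=N)oc12` has not been measured. It differs from compound 1 in one place: cyano in place of methoxy on an aromatic carbon. Cut one bond further out, the same difference reads 4-methoxyphenyl to 4-cyanophenyl. No measured pair shows this exchange, so there is no precedent among these compounds for its size in this assay. On the numbers available, the step from compound 1 to compound 3 is expected to be small, a number 2 percentage points lower from compound 1 to compound 3 (within the scatter), with no change beyond the scatter foreseen in either direction. Compound 3 is therefore estimated to give 35% in this assay, with a range from 15% to 55%.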

Compound 3, a percentage reported as inhibition, at one concentration (the size of the read-out at that concentration, not a potency): 18%
Estimate against measurement, compound 3: 17 percentage points above, within the range that was stated.
By their numbers in this assay, from the lowest: compounds 3 and 2 (each within the scatter of the next); then compound 1.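

Exchanging methoxy for cyano on an aromatic carbon para to a large group, which turns 4-methoxyphenyl into 4-cyanophenyl, proves to matter in this assay, giving the first step read at this position (a number 19 percentage points lower from compound 1 to compound 3 (beyond the scatter)). The response to this position is therefore not flat, even though the entering and leaving groups match in what can be counted: each has 2 heavy atoms and 1 hydrogen-bond acceptor, with no ring and no net charge, and they differ in carbon and nitrogen with a triple bond against carbon and oxygen. Nothing measured here accounts for the size of this step.

From the compounds shown here alone, this single pair gives one direction of change and no trend, so it remains open whether an amine, a carboxylic acid or a longer chain such as ethoxy at the same position would stay near compound 1 or fall near compound 3. Going by these compounds alone, it also remains open whether the same exchange would give a step of similar size on a core other than the one shared by compound 1 and compound 3.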